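Cytotoxicity notes on a shared core, compounds 1 to 3

The compounds below may be only part of what the source reports. "The series", "measured", "known", "first", "only" and "open" are said of these compounds alone.

Measured so far in an ADME assay on HEL cells (Homo sapiens) for cytotoxicity, with a stated time of 3 days; a higher number here means that more compound is tolerated, a lower number that less compound is tolerated:
compound 1 `Cc1cc(-c2ccc(C=O)cc2)cn2c(CSCCc3ccccc3)cnc12` gives 9.4 ug/mL
compound 2 `Cc1cc(-n2cccc2)cn2c(CSCCc3ccccc3)cnc12` gives 11 ug/mL

For the measured compounds named here, compound 2 holds the higher of the two numbers in this assay, but its only neighbour, compound 1, sits within the scatter, so no order between the two can be read. Compound 3 `Cc1cc(Sc2ccc(N)cc2)cn2c(CSCCc3ccccc3)cnc12` differs from compound 2 in one place: (4-aminophenyl)sulfanyl in place of 1H-pyrrol-1-yl on an aromatic carbon. A single measured step touches the same aromatic carbon, a 1.2-fold higher number from compound 1 to compound 2 (0.07 log units; within the scatter), and it left the number unmoved beyond the scatter. That step concerns a different pair of groups, so it shows only that one earlier replacement at this carbon made no difference; it gives no direction for the present change. On this basis no step beyond the scatter is expected. For compound 3 the expected step is a 1.1-fold lower number from compound 2 to compound 3 (0.04 log units; within the scatter). Compound 3 is therefore estimated at 10 ug/mL, with a range from 4 ug/mL to 25 ug/mL.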

Compound 3, half-maximal cytotoxic concentration: 23 ug/mL
The estimate for compound 3 lay 2.3-fold (0.36 log units) below the measured number; measured number inside the range.
By their numbers in this assay, from the lowest: compounds 1 and 2 (each within the scatter of the next); then compound 3.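

In this assay this aromatic carbon proves able to shift the number: the (4-aminophenyl)sulfanyl group gives a 2.1-fold higher number from compound 2 to compound 3 (0.32 log units; beyond the scatter) and also a 2.4-fold higher number from compound 1 to compound 3 (0.39 log units; beyond the scatter) against the two earlier groups. For the compounds shown here, the earlier replacement at this carbon stayed within the scatter, so this is the first change here to move the number beyond it, though only modestly and towards more compound tolerated. Nothing measured here explains the shift.

The change brings in the sulfur link and the amine together, so the compounds shown do not tell which of the two goes with the higher number; a phenylsulfanyl group without the amine, or a 4-aminophenyl group joined directly to the carbon, would separate them. On these data alone, whether a carboxylic acid in place of the amine would give a similar number also stays open.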